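Pyrazin-2-yl for 4-Phenylphenyl on the Ring Nitrogen

The source may hold more compounds than are shown below. What is called first, only, known or untested is meant among the compounds shown, and "the series" means these compounds.

Compound 2 `O=C(NCCCCc1ccccc1)c1cccc(C2SCC(=O)N2c2ccc(-c3ccccc3)cc2)c1` bears a 4-phenylphenyl group on the amide-type nitrogen of the shared core. In a functional assay on HOS-TE85 cells (Homo sapiens) for inhibition, read by CCK-8 assay, with a stated time of 72 h (a higher number here means a weaker inhibitor, a lower number a stronger inhibitor), compound 2 gives only a limit, > 1000 nM, not a number. Compound 1 `COc1ccc(F)cc1N1C(=O)CSC1c1cccc(C(=O)NCCCCn2cccn2)c1` and compound 3 `O=C(NCCCCn1cccn1)c1cccc(C2SCC(=O)N2c2cc(Br)ccn2)c1` carry smaller groups at that nitrogen and also differ in the chain; in this assay compound 1 gives 97.3 nM and compound 3 gives 105 nM. Within the data shown here, the one measured swap at that position is a 1.1-fold higher number from compound 1 to compound 3 (0.03 log units; within the scatter). Compound 4 `O=C(NCCCCc1ccccc1)c1cccc(C2SCC(=O)N2c2cnccn2)c1` is not yet measured. pyrazin-2-yl in place of 4-phenylphenyl on an amide-type nitrogen in a ring That earlier swap between two small groups changed little, and compound 2 sits at the limit (the limit of > 1000 nM in this assay, at which 1 of the 3 values shown sits), so the size of the step is uncertain. Compound 4 is expected near 400 nM, between 100 nM and 2000 nM. The expected step is an at least 2.5-fold lower number from compound 2 to compound 4 (0.39 log units; beyond the scatter).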

Compound 4, half-maximal inhibitory concentration: > 1000 nM
Compound 4: a limit, no number (the forecaster's own chance of this, stated with the estimate: 30%); middle value at least 2.5-fold (0.39 log units) from the limit.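

Compound 2 and compound 4 each give a limit, not a number, so the step between them cannot be read: the limit of > 1000 nM in this assay, at which 2 of the 4 values shown sit.

The compounds shown leave open whether 4-phenylphenyl or pyrazin-2-yl on the amide-type nitrogen gives the stronger inhibitor.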